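A few compounds are considered here, and "the series" means these few. Any claim that something is new, unique, unknown or untested is made for them only; others in the source may bear on it.

Working notes on the sulfonamide series.

Compound 1 `O=S(=O)(Nc1ccc(-c2nc3ccccc3o2)cc1)c1ccccc1F` was tested in an ADME assay on HEK293 cells (Homo sapiens) for cytotoxicity, read by resazurin assay, with a stated time of 48 h; on this read-out higher numbers stand for lower toxicity in this test and lower numbers for higher toxicity in this test. In this assay compound 1 gives > 100000 nM, which is a limit of the assay and not a measured number; compound 1 therefore stands at the limit of > 100000 nM in this assay, at which 1 of the 2 values shown sits. A second member, compound 2 `O=S(=O)(Nc1ccc2oc(-c3ccccc3)nc2c1)c1ccccc1Cl`, carries a different arrangement of the same pieces and in this assay compound 2 gives 73000 nM. Going by the values given here, no single-point step between the two measured compounds can be drawn, so the two values are only taken as both lying at the low-toxicity end of the read-out.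

Compound 3 `COc1ccc(S(=O)(=O)Nc2ccc(-c3nc4ccccc4o3)cc2)cc1` is not yet measured. It differs from compound 1 by 4-methoxyphenyl in place of 2-fluorophenyl on a sulfonyl sulfur. Nothing measured in this set speaks to a shift in either direction for this exchange, so no step beyond the usual scatter is expected, and the expected step is a number no higher from compound 1 to compound 3 (the limit leaves the size open). Compound 3 is accordingly expected to give about 100000 nM in this assay, within 50000 nM to 200000 nM.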

Compound 3, half-maximal cytotoxic concentration: > 100000 nM
Compound 3 was reported as a limit (the forecaster's own chance of this, stated with the estimate: 60%); the middle value sits exactly at the limit.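

In this assay compound 1 and compound 3 are both reported only as limits, so no step can be read between them: the limit of > 100000 nM in this assay, at which 2 of the 3 values shown sit. The compounds shown leave open whether 4-methoxyphenyl in place of 2-fluorophenyl on a sulfonyl sulfur shifts this read-out in either direction.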